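A few compounds are considered here, and "the series" means these few. Any claim that something is new, unique, unknown or untested is made for them only; others in the source may bear on it.

Measured compounds:
compound 1 `O=C(O)c1cccc(C2CC2c2ccc(OCc3c(-c4c(Cl)cccc4Cl)noc3C3CC3)cc2Cl)c1`: 32 nM
compound 2 `CC(C)n1nc(C(=O)O)cc1C1CC1c1ccc(OCc2c(-c3c(Cl)cccc3Cl)noc2C2CC2)cc1Cl`: 7 nM
compound 3 `O=C(O)c1ccc(C2CC2c2ccc(OCc3c(-c4c(Cl)cccc4Cl)noc3C3CC3)cc2Cl)cn1`: 66 nM

In an assay on isolated protein for agonist activity at Bile acid receptor (Homo sapiens), read by FRET (on this read-out higher numbers stand for an effect only at larger amounts of compound and lower numbers for an effect already at smaller amounts), compound 2 gives the lowest of the three numbers: compound 1 sits a 4.6-fold lower number from compound 1 to compound 2 (0.66 log units; beyond the scatter) away, compound 3 stands a 9.4-fold higher number from compound 2 to compound 3 (0.97 log units; beyond the scatter) off. Compound 4 `CC(C)n1nc(C(=O)O)cc1[C@@H]1C[C@H]1c1ccc(OCc2c(-c3c(Cl)cccc3Cl)noc2C2CC2)cc1Cl` keeps every atom and bond of compound 2; the change is the two compounds have the same atoms and bonds; at least one stereo element is drawn with a configuration in one of them and without one in the other: 2 of 2 stereo elements differ; a stereocentre at a saturated ring carbon is drawn without a configuration in compound 2 and R in compound 4; a stereocentre at a saturated ring carbon is drawn without a configuration in compound 2 and R in compound 4. Among the compounds with values here, none of the measured steps touches a stereo element, so the steps from compound 1 to compound 2 and from compound 2 to compound 3 do not bear on it; they only fix the starting point. A single drawn configuration of a compound whose number was obtained without configuration is expected to give a number within or somewhat below it in this assay, so compound 4 is estimated at 4 nM with a range of 1.5 nM to 15 nM, i.e. an expected step of a 1.8-fold lower number from compound 2 to compound 4 (0.24 log units; within the scatter).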

Compound 4, half-maximal effective concentration: 4 nM
The estimate for compound 4 equals the measured number at the digits printed; the range from low to high includes it.
By their numbers in this assay, from the lowest: compounds 4 and 2 (each within the scatter of the next); then compound 1; then compound 3.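

In this assay, within the data shown here, this is the first step that touches a stereo element rather than the group on the saturated ring carbon (a 1.8-fold lower number from compound 2 to compound 4 (0.24 log units; within the scatter)). Drawing both stereocentres as R therefore gives no difference that can be told from the scatter. The comparison concerns the drawing alone: the fact that one of compounds 2 and 4 is drawn with a defined configuration and the other without, at the place where they differ

Open, as far as these compounds go, is how the mirror-image configuration at these ring carbons reads in this assay. Also open, from the compounds shown here alone, is what a tert-butyl in place of the isopropyl of 3-carboxy-1-isopropyl-1H-pyrazol-5-yl, or a primary amide in place of its carboxy group, would do.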